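Removing the Methoxy Groups From the Benzylamine Arm

The source may hold more compounds than are shown below. What is called first, only, known or untested is meant among the compounds shown, and "the series" means these compounds.

The series shares one core and varies the group attached to the nitrogen on that core. Compound 1 `COc1ccc(CNc2nc3cc(N)cc(N)c3nc2-c2ccccc2)cc1OC` carries a 3,4-dimethoxyphenyl on the saturated chain carbon bound to that nitrogen; in a functional assay on HOP-92 cells (Homo sapiens) for inhibition, read by sulforhodamine B assay, with a stated time of 48 h (a higher number here means a weaker inhibitor of growth, a lower number a stronger inhibitor of growth), compound 1 gives 13500 nM. Among the three measured compounds this is the second highest number. Compound 3 `CCOC(=O)[C@H](CCC(=O)O)NC(=O)c1ccc(Oc2nc3cc(N)cc(N)c3nc2-c2ccccc2)cc1`, which carries a different arm altogether, gives 30200 nM, a number a little higher than that of compound 1. Going by the values given here, compound 2 `COc1cc(CNc2nc3cc(N)cc(N)c3nc2-c2ccccc2)cc(OC)c1OC` gives 1200 nM; the single step of an 11-fold lower number from compound 1 to compound 2 (1.05 log units; beyond the scatter) comes from a methoxy in place of hydrogen on an aromatic carbon, and it is the only one-place step the set offers.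

Compound 4 `Nc1cc(N)c2nc(-c3ccccc3)c(NCc3ccc(F)cc3)nc2c1` is not yet measured. It differs from compound 1 by 4-fluorophenyl in place of 3,4-dimethoxyphenyl on a saturated chain carbon bound to a nitrogen on an aromatic ring. Among the compounds with values here, the one bearing step runs the other way: adding a methoxy lowered the number strongly, so taking both away, with fluorine entering instead, is expected to raise it or at best to leave it near the scatter. Compound 4 is therefore estimated at 25000 nM, with a range from 8000 nM to 80000 nM; the expected step of a 1.9-fold higher number from compound 1 to compound 4 (0.27 log units; within the scatter) is modest and uncertain in size.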

Compound 4, concentration for 50% growth inhibition: 3310 nM
Compound 4: the middle estimate sits 7.6-fold (0.88 log units) above what was measured, outside the stated range (below it).
By their numbers in this assay, from the lowest: compound 2; then compound 4; then compound 1; then compound 3.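

At this position the 3,4-dimethoxyphenyl group is not needed for a lower number in this assay: 4-fluorophenyl, with fewer heavy atoms and no hydrogen-bond acceptors, gives a 4.1-fold lower number from compound 1 to compound 4 (0.61 log units; beyond the scatter). The earlier step had suggested that more methoxy groups lower the number, but compound 4 goes against that reading, since it carries no methoxy group and still sits below compound 1, while compound 2, with the most methoxy groups, remains the lowest of the benzylamine compounds at 1200 nM, against compound 4 at 3310 nM. Nothing measured here explains why either change moves the number, so the direction of this step stands as an observation only.

Since this single change removes both methoxy groups and brings in fluorine, the compounds shown leave open how much of the step belongs to each, a question that a plain phenyl on the same carbon would bear on directly. They also leave open whether chlorine, a trifluoromethyl group, an amine or a carboxylic acid on that ring, or a longer chain between the ring and the nitrogen, would lower the number further or raise it again.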